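Cytotoxicity notes: from compound 2 to compound 3

The compounds below may be only part of what the source reports. "The series", "measured", "known", "first", "only" and "open" are said of these compounds alone.

Measured so far:
compound 1 `CCOC(=O)CCCCCOc1cccc(CN(C(=O)c2ccc(-c3cccc(-c4nnc(C)o4)c3)cc2)C(C)C)c1` — > 26000 nM
compound 2 `CCOC(=O)CCCCCOc1cccc(CN(C(=O)c2ccc(-c3ccc4cc[nH]c4c3)cc2)C(C)C)c1` — > 26000 nM

In an ADME assay on Raji cells (Homo sapiens) for cytotoxicity, read by CellTiter-Glo and resazurin assay, with a stated time of 72 h (on this read-out lower numbers stand for an effect already at smaller amounts and higher numbers for an effect only at larger amounts of compound), compound 1 gives only a limit of the assay, > 26000 nM. Compound 2 also gives only a limit, > 26000 nM. Both values sit at the limit of > 26000 nM in this assay, at which 2 of the 2 values shown sit, so the step that the two limits leave unreadable from compound 1 to compound 2 cannot be read, and compound 2 stands nowhere more exactly than at that limit on the numbers shown.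

Compound 3 `CCOC(=O)CCCCCOc1cccc(CN(C(=O)c2ccc(-c3cc(F)cc(OC)c3)cc2)C(C)C)c1` differs from compound 2 by 3-fluoro-5-methoxyphenyl in place of 1H-indol-6-yl on an aromatic carbon. Within the data shown here, the one measured step that touches this position, a step that the two limits leave unreadable from compound 1 to compound 2, is itself a change of the group on this aromatic carbon, but with both ends at a limit it offers no size in either direction. Among the measured compounds shown here, no measured step therefore gives a readable basis for a shift beyond the scatter, and with both measured compounds at the limit the most that can be expected is that compound 3 also sits there.

For compound 3 the estimate is 40000 nM with a range from 15000 nM to 100000 nM. The expected step that the limit leaves unreadable from compound 2 to compound 3 is accordingly none that can be read beyond the limit.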

Compound 3, half-maximal effective concentration: > 26000 nM
Compound 3 gave a limit, no number; the forecaster's own chance of this, stated with the estimate: 85%; the middle value is on the limit's open side.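

In this assay compound 3 gives only a limit, as do compound 1 and compound 2, so no step among these compounds can be read: the limit of > 26000 nM in this assay, at which 3 of the 3 values shown sit. The compounds shown leave open whether the group on this aromatic carbon changes the half-maximal effective concentration at all; none of them gives a number.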